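Pyrrolidine to piperidine swap on the propoxy side chain

The source may report more compounds than this note shows. Statements on the series, on what has been measured and on what is new or still open speak of the compounds shown alone.

Measured so far in a functional assay on U-87MG ATCC cells (Homo sapiens) for inhibition, read by MTT assay, with a stated time of 72 h; on this read-out lower numbers stand for stronger inhibition and higher numbers for weaker inhibition:
compound 1, `COc1cc2c(Oc3ccc(NC(=O)c4nn(-c5cccc(F)c5)c(=O)cc4C)cc3F)ccnc2cc1OCCCN1CCCC1`: 1700 nM
compound 2, `COc1cc2c(Oc3ccc(NC(=O)c4nn(-c5cccc(F)c5)c(=O)cc4C)cc3F)ccnc2cc1OCCCN1CCCCC1`: 1500 nM
compound 3, `COc1ccc(-n2nc(C(=O)Nc3ccc(Oc4ccnc5cc(OCCCN6CCCC6)c(OC)cc45)c(F)c3)c(C)cc2=O)cc1`: 2960 nM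

Compound 1 and compound 2 differ by piperidin-1-yl in place of pyrrolidin-1-yl on a saturated chain carbon, three bonds along the chain from an oxygen on an aromatic ring; this gave a 1.1-fold lower number from compound 1 to compound 2 (0.05 log units; within the scatter). The core of compound 3 differs from that of compound 1 by 4-methoxyphenyl in place of 3-fluorophenyl on an aromatic nitrogen, and the step was a 1.7-fold higher number from compound 1 to compound 3 (0.24 log units; within the scatter).

Compound 4, `COc1ccc(-n2nc(C(=O)Nc3ccc(Oc4ccnc5cc(OCCCN6CCCCC6)c(OC)cc45)c(F)c3)c(C)cc2=O)cc1`, is not yet measured. It differs from compound 3 by piperidin-1-yl in place of pyrrolidin-1-yl on a saturated chain carbon, three bonds along the chain from an oxygen on an aromatic ring, whose place reads word for word as the place in the change from compound 1 to compound 2, so this is the same change on the other core. The expected step in this assay is therefore a 1.1-fold lower number from compound 3 to compound 4 (0.04 log units; within the scatter), resting on the earlier 1.1-fold lower number from compound 1 to compound 2 (0.05 log units; within the scatter), which stayed within the scatter. For compound 4 the estimate is 2700 nM, with a range from 1400 nM to 5500 nM.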

Compound 4, half-maximal inhibitory concentration: 1800 nM
Beside the measured number, compound 4's estimate is 1.5-fold (0.18 log units) above it; measured number inside the range.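

In this assay, piperidin-1-yl in place of pyrrolidin-1-yl gave a 1.6-fold lower number from compound 3 to compound 4 (0.22 log units; within the scatter), and the change carries from one core to the other without a difference beyond the scatter: the same change on two cores in this assay, a 1.1-fold lower number (0.05 log units; within the scatter) from compound 1 to compound 2 and a 1.6-fold lower number (0.22 log units; within the scatter) from compound 3 to compound 4, 1.5-fold (0.16 log units) apart, within the scatter of two such steps

4-Methoxyphenyl in place of 3-fluorophenyl gave a 1.2-fold higher number from compound 2 to compound 4 (0.08 log units; within the scatter), and this change also reads alike on both partners: the same change on two cores in this assay, a 1.7-fold higher number (0.24 log units; within the scatter) from compound 1 to compound 3 and a 1.2-fold higher number (0.08 log units; within the scatter) from compound 2 to compound 4, 1.5-fold (0.16 log units) apart, within the scatter of two such steps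

Among the compounds shown here, every step here lies within the scatter, so the agreement shows only that neither change separates these four compounds; it does not show that a change with a step beyond the scatter would carry across cores in the same way.

Open, on these data alone, is whether a morpholin-4-yl or dimethylamino group on the same chain carbon, or a longer chain, would give a step beyond the scatter. The same question holds for an unsubstituted phenyl or a 4-chlorophenyl on the aromatic nitrogen.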